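Swapping the Pyridine Ring Back to Plain Phenyl

A few compounds are considered here, and "the series" means these few. Any claim that something is new, unique, unknown or untested is made for them only; others in the source may bear on it.

Among the measured compounds shown here, compound 2 `CCN(Cc1ccncc1)c1ccc(C(=O)N2CCc3ccc(OS(N)(=O)=O)cc3C2)cc1` gives 47% in an assay on HEK293 cells for inhibition of Steryl-sulfatase (Homo sapiens), tested at 0.1 uM (on this read-out higher numbers stand for a stronger effect at the one concentration tested and lower numbers for a weaker effect), the lower of the two numbers known so far; compound 1 `CCN(Cc1ccc(Br)cc1)c1ccc(C(=O)N2CCc3ccc(OS(N)(=O)=O)cc3C2)cc1` gives 78.2%. For the measured compounds named here, the single measured step bears directly on what follows: a number 31.2 percentage points lower from compound 1 to compound 2 (beyond the scatter). Compound 3 `CCN(Cc1ccccc1)c1ccc(C(=O)N2CCc3ccc(OS(N)(=O)=O)cc3C2)cc1` differs from compound 2 only by phenyl in place of pyridin-4-yl on a saturated chain carbon bound to a nitrogen on an aromatic ring, which partly reverses that earlier exchange. For compound 3 a rise is expected, a number 21 percentage points higher from compound 2 to compound 3 (beyond the scatter), somewhat smaller than the measured step. The estimate for compound 3 in this assay is 68%, with a range from 50% to 85%.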

Compound 3, a percentage reported as inhibition, at one concentration (the size of the read-out at that concentration, not a potency): 66.9%
Beside the measured number, compound 3's estimate is 1.1 percentage points above it; the measured number falls inside the stated range.
By their numbers in this assay, from the lowest: compound 2; then compound 3; then compound 1.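

In this assay, phenyl in place of pyridin-4-yl gives a number 19.9 percentage points higher from compound 2 to compound 3 (beyond the scatter) and so recovers much of the earlier drop with a ring of carbon only. Hydrogen in place of bromo on an aromatic carbon gives a number 11.3 percentage points lower from compound 1 to compound 3 (beyond the scatter) and shows that the bromo also counts, apart from the ring itself. Nothing available here gives a reason for either step. Still open, as far as these compounds go, is whether a chloro or a methoxy group in place of bromo would match compound 1, and whether pyridin-3-yl would behave like pyridin-4-yl.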